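Working notes: hydrogen in place of trifluoromethyl

The source may hold more compounds than are shown below. What is called first, only, known or untested is meant among the compounds shown, and "the series" means these compounds.

Measured so far:
compound 1 `CN(C)C(=O)c1cc2cnc(Nc3ccc(NC(=O)C4(C(=O)Nc5ccc(F)cc5)CC4)cc3F)nc2n1C1CCCC1`: -0.9%
compound 2 `CN(C)C(=O)c1cc2cnc(Nc3ccc(NC(=O)C4(C(=O)Nc5ccc(Cl)c(C(F)(F)F)c5)CC4)cc3)nc2n1C1CCCC1`: -2.4%
compound 3 `CN(C)C(=O)c1cc2cnc(Nc3ccc(N)cn3)nc2n1C1CCCC1`: 12.3%

In a functional assay on OVCAR-5 cells (Homo sapiens) for inhibition, read by CCK-8 assay, with a stated time of 72 h, tested at 1 uM (a lower number here means less inhibition of growth, a higher number more inhibition of growth at the concentration tested), compound 2 gives the lowest of the three numbers. Compound 1 lies within the scatter of compound 2, so the two cannot be ordered; compound 3 lies beyond the scatter above compound 2.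

Compound 4 `CN(C)C(=O)c1cc2cnc(Nc3ccc(NC(=O)C4(C(=O)Nc5ccc(Cl)cc5)CC4)cc3)nc2n1C1CCCC1` differs from compound 2 in one place: hydrogen in place of trifluoromethyl on an aromatic carbon. Within the data shown here, no pair of measured compounds shares a single-point difference, so the series itself offers no measured step of this kind to lean on.

The step of a number 2.4 percentage points higher from compound 2 to compound 4 (within the scatter) is expected to be none beyond the scatter.

Compound 4 is estimated at 0%, with a range from -10% to 12%.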

Compound 4, percent growth inhibition at one concentration: 8.1%
Compound 4: the middle estimate sits 8.1 percentage points below what was measured, within the range that was stated.
By their numbers in this assay, from the lowest: compounds 2, 1, 4 and 3 (each within the scatter of the next, the first and the last beyond it).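

In this assay, among these compounds, the change from 4-chloro-3-(trifluoromethyl)phenyl to 4-chlorophenyl gives a number 10.5 percentage points higher from compound 2 to compound 4 (beyond the scatter) and is the first single-place step. It shows that this aromatic carbon, ortho to the chloro group, is not silent: trifluoromethyl can leave without any loss of growth inhibition at the concentration tested. Nothing given here accounts for the step. Open, on these data alone, is whether a methoxy group, a nitrile or an amine on this carbon would read like hydrogen or like trifluoromethyl. Also open, as far as these compounds go, is whether the step recurs without the chloro group.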